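A few compounds are considered here, and "the series" means these few. Any claim that something is new, unique, unknown or untested is made for them only; others in the source may bear on it.

Measured compounds:
compound 1, `O=C(NCCCCc1ccccc1)n1c(=O)oc2ccccc21`: 64 nM in an assay on HEK293 cells for inhibition of acid ceramidase (Homo sapiens), with a stated time of 10 min; on this read-out lower numbers stand for stronger inhibition and higher numbers for weaker inhibition
compound 2, `O=C(NCCCCc1ccccc1)n1c(=O)oc2cc(-c3ccc(F)cc3)ccc21`: 79 nM
compound 3, `O=C(c1ccccc1)c1ccc2c(c1)oc(=O)n2C(=O)NCCCCc1ccccc1`: 29 nM

Compound 3 holds the lowest number of the three, set apart from compound 1 by a 2.2-fold lower number from compound 1 to compound 3 (0.34 log units; beyond the scatter) and from compound 2 by a 2.7-fold lower number from compound 2 to compound 3 (0.44 log units; beyond the scatter); both steps lie beyond the scatter, though each is modest.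

Compound 4, `COc1ccc(-c2ccc3c(c2)oc(=O)n3C(=O)NCCCCc2ccccc2)cc1`, awaits measurement. Against compound 3 the change is 4-methoxyphenyl in place of benzoyl on an aromatic carbon. Among the compounds with values here, three measured steps bear on it. Placing benzoyl on the core gave a 2.2-fold lower number from compound 1 to compound 3 (0.34 log units; beyond the scatter). Placing 4-fluorophenyl on the same carbon gave a 1.2-fold higher number from compound 1 to compound 2 (0.09 log units; within the scatter), a step within the scatter. Swapping 4-fluorophenyl for benzoyl gave a 2.7-fold lower number from compound 2 to compound 3 (0.44 log units; beyond the scatter). Compound 4 carries 4-methoxyphenyl, a directly attached phenyl group like that of compound 2, so the reverse of the step from compound 2 to compound 3 is the nearest guide, and a modestly higher number in this assay is expected. Within the data shown here, no measured pair separates 4-methoxyphenyl from 4-fluorophenyl, so the range is kept wide.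

For compound 4 in this assay the estimate is 65 nM, with a range of 30 nM to 140 nM. The expected step is a 2.2-fold higher number from compound 3 to compound 4 (0.35 log units; beyond the scatter).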

Compound 4, half-maximal inhibitory concentration: 67 nM
Beside the measured number, compound 4's estimate is 1.0-fold (0.01 log units) below it; the measured number falls inside the stated range.
By their numbers in this assay, from the lowest: compound 3; then compounds 1, 4 and 2 (each within the scatter of the next).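

In this assay, 4-methoxyphenyl in place of benzoyl gives a 2.3-fold higher number from compound 3 to compound 4 (0.36 log units; beyond the scatter) on this aromatic carbon, even though the two groups match in heavy atoms, aromatic ring and hydrogen-bond acceptors and differ in the double bond outside aromatic rings, which only benzoyl carries. The directly attached phenyl groups now form a small set: methoxy in place of fluoro gives a 1.2-fold lower number from compound 2 to compound 4 (0.07 log units; within the scatter) and 4-methoxyphenyl in place of hydrogen gives a 1.0-fold higher number from compound 1 to compound 4 (0.02 log units; within the scatter), so neither the para substituent on that phenyl ring nor the presence of the ring itself separates these compounds, and among the four only benzoyl stands apart from the unsubstituted core. The data on hand offer no explanation for the gap between benzoyl and 4-methoxyphenyl.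

On these data alone, whether the lower number of compound 3 depends on the carbonyl alone or on the carbonyl together with its phenyl ring remains open; an acetyl group, or a methylene link in place of the carbonyl, would separate the two. Also open, as far as these compounds go, is how a benzoyl group carrying a methoxy or an amine on its phenyl ring would read in this assay on this carbon.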